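A few compounds are considered here, and "the series" means these few. Any claim that something is new, unique, unknown or untested is made for them only; others in the source may bear on it.

Measured in a functional assay on SMMC-7721 cells (Homo sapiens) for cytotoxicity, read by MTT assay, with a stated time of 24 h; on this read-out higher numbers stand for weaker inhibition and lower numbers for stronger inhibition:
- Compound 1 `O=C1/C(=C/c2cccnc2)CN(S(=O)(=O)c2ccc([N+](=O)[O-])cc2)C/C1=C\c1ccccc1F`: > 20000 nM, a limit of the assay and not a number
- Compound 2 `O=C1/C(=C/c2cccnc2)CN(S(=O)(=O)c2ccc(Br)cc2)C/C1=C\c1ccccc1F`: 9100 nM
- Compound 3 `CC(=O)Nc1ccc(S(=O)(=O)N2C/C(=C\c3cccnc3)C(=O)/C(=C/c3ccccc3F)C2)cc1`: 10900 nM

Only compound 2 and compound 3 give actual numbers in this assay, and the two lie within the scatter of each other, with a 1.2-fold higher number from compound 2 to compound 3 (0.08 log units; within the scatter). The next compound, compound 4 `O=C1/C(=C/c2ccncc2)CN(S(=O)(=O)c2ccc(Br)cc2)C/C1=C\c1ccccc1F`, keeps everything in compound 2 except one group: pyridin-4-yl in place of pyridin-3-yl on a double-bonded chain carbon bound to a double-bonded ring carbon. In words, it carries pyridin-4-yl in place of pyridin-3-yl on a double-bonded chain carbon bound to a double-bonded ring carbon.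

The measured steps give no direct guide to this change. All of them exchange groups on an aromatic carbon, and none alters the pyridinyl group. They are an at least 2.1-fold lower number from compound 1 to compound 2 (0.34 log units; beyond the scatter), an at least 1.8-fold lower number from compound 1 to compound 3 (0.26 log units; that floor lies within the scatter) and a 1.2-fold higher number from compound 2 to compound 3 (0.08 log units; within the scatter). Only the first of these is shown to exceed the scatter, and it replaces nitro, which compound 4 does not carry. With no measured pyridinyl exchange to draw on, no step beyond the scatter is expected, and the expected result is a 1.1-fold higher number from compound 2 to compound 4 (0.04 log units; within the scatter). For compound 4 the estimated value is 10000 nM, with an expected range from 4500 nM to 22000 nM.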

Compound 4, half-maximal inhibitory concentration: 12600 nM
Estimate against measurement, compound 4: 1.3-fold (0.10 log units) below; measured number inside the range.
By their numbers in this assay, from the lowest: compounds 2, 3 and 4 (each within the scatter of the next). At a limit, above all of these: compound 1.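

Within the data shown here, compound 4 gives the first reading of a change at this position, pyridin-4-yl in place of pyridin-3-yl on a double-bonded chain carbon bound to a double-bonded ring carbon, and in this assay the result is a 1.4-fold higher number from compound 2 to compound 4 (0.14 log units; within the scatter). The two groups have the same atoms, joined differently, and with the bromo group and the rest of the structure held constant, this exchange does not separate compound 2 from compound 4 beyond the usual scatter of the assay. This is a single exchange on a single background, so it shows only that this one swap leaves the read-out within the scatter, and nothing shown gives a reason for that result.

Going by these compounds, it remains open whether a different group at this place, such as pyridin-2-yl, a plain phenyl or a phenyl carrying an amine or a carboxylic acid, would move the number beyond the scatter. On these data alone, it is also open whether the same exchange would give the same result with acetamido or nitro in place of bromo on the other aromatic ring.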